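A Methoxy for a Fluoro on the Outer Phenyl Ring

The compounds below may be only part of what the source reports. "The series", "measured", "known", "first", "only" and "open" are said of these compounds alone.

Of the compounds shown here, three built on a shared core have been tested in a functional assay on HL-60 cells (Homo sapiens) for cytotoxicity, read by MTT assay, with a stated time of 4 days; a higher number here means a weaker inhibitor, a lower number a stronger inhibitor. Compound 1 `C=C1C[C@]23C[C@@]1(O)CC[C@H]2c1cc(Br)c(O)c(C)c1[C@@H]3Cn1cc(-c2ccccc2)nn1` gives > 20000 nM, which is a limit of the assay rather than a number. Compound 3 `Cc1ccc(S(=O)(=O)Oc2ccc3c(c2C)[C@H](Cn2cc(-c4ccc(Cl)cc4)nn2)[C@@]24CC(=O)[C@@](C)(CC[C@@H]32)C4)cc1` likewise gives > 20000 nM, again a limit. Among the compounds with values here, compound 2 `C=C1C(=O)[C@]23C[C@@]1(O)CC[C@H]2c1ccc(OS(=O)(=O)c2ccc(C)cc2)c(C)c1[C@@H]3Cn1cc(-c2ccc(F)cc2)nn1` is the only compound with a measured number, giving 1290 nM in this assay; it stands alone among the values shown, as the limit of > 20000 nM in this assay, at which 2 of the 3 values shown sit, describes, so there is no second number to compare it with.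

Compound 4 `C=C1C(=O)[C@]23C[C@@]1(O)CC[C@H]2c1ccc(OS(=O)(=O)c2ccc(C)cc2)c(C)c1[C@@H]3Cn1cc(-c2ccc(OC)cc2)nn1` has not yet been measured. It differs from compound 2 in one place: methoxy in place of fluoro on an aromatic carbon. Within the data shown here, no step between two measured compounds is available to show how large such a swap might be, so the expectation rests on the change itself. The expected step from compound 2 to compound 4 in this assay is a 1.2-fold higher number from compound 2 to compound 4 (0.07 log units; within the scatter), which is no more than the usual scatter, in either direction. On that basis compound 4 is estimated at 1500 nM in this assay, with a range from 500 nM to 5000 nM within which most repeat measurements would be expected to fall.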

Compound 4, half-maximal inhibitory concentration: 1020 nM
Estimate against measurement, compound 4: 1.5-fold (0.17 log units) above; the range from low to high includes it.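

In this assay, within the data shown here, putting methoxy in place of fluoro gives a 1.3-fold lower number from compound 2 to compound 4 (0.10 log units; within the scatter), and this is the first step that can be read at all. It shows that this place, on an aromatic carbon para to a large group, can carry either group with no change that stands out from the scatter, even though methoxy is the bigger of the two and brings a hydrogen-bond acceptor that fluoro lacks. Nothing shown here gives a reason why the swap leaves the number where it is.

Steps from this pair to the remaining compounds cannot be read, since those compounds differ from it in more than one place and their values are limits, not numbers: the limit of > 20000 nM in this assay, at which 2 of the 4 values shown sit. It remains open whether this tolerance reaches beyond the 4-fluorophenyl to 4-methoxyphenyl swap, for instance whether an amine, a carboxylic acid or a longer chain such as ethoxy at the same place would also stay within the scatter or would finally move the number.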